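The compounds below may be only part of what the source reports. "The series", "measured", "known", "first", "only" and "open" are said of these compounds alone.

Compound 1 `CN1CCN(c2nc(-n3ccc4ccccc43)c3ccccc3n2)CC1` gives 11.5 ug/mL in a functional assay on C-33-A cells (Homo sapiens) for antiproliferative activity, read by MTT assay; on this read-out lower numbers stand for stronger inhibition and higher numbers for weaker inhibition. Among the compounds with values here, compound 2 `c1ccc(N2CCN(c3nc(-n4ccc5ccccc54)c4ccccc4n3)CC2)cc1` gives 50 ug/mL in this assay, the higher of the two numbers; the single step measured so far, a 4.3-fold higher number from compound 1 to compound 2 (0.64 log units; beyond the scatter), is the only comparison in hand. Compound 3 `Fc1ccc(N2CCN(c3nc(-n4ccc5ccccc54)c4ccccc4n3)CC2)cc1` differs from compound 2 by fluoro in place of hydrogen on an aromatic carbon. Within the data shown here, no measured step bears on fluoro in place of hydrogen on an aromatic carbon, and the methyl-to-phenyl step gives no guide to a change on the phenyl itself. The expected step is therefore a 1.3-fold lower number from compound 2 to compound 3 (0.10 log units; within the scatter), not beyond the scatter. Compound 3 is estimated at 40 ug/mL, within a range of 15 ug/mL to 100 ug/mL.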

Compound 3, half-maximal inhibitory concentration: 50 ug/mL
Compound 3: middle estimate off by 1.3-fold (0.10 log units), on the low side; the measured number falls inside the stated range.
By their numbers in this assay, from the lowest: compound 1; then compounds 2 and 3 (each within the scatter of the next).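

Fluoro on the aromatic carbon para to a large group is the first change on the phenyl itself, and in this assay it moves nothing (no change at the digits printed from compound 2 to compound 3 (within the scatter)). The gap to the methyl end stays as it was with 4-fluorophenyl in place of phenyl (a 4.3-fold higher number from compound 1 to compound 3 (0.64 log units; beyond the scatter)). Nothing at hand gives a reason for either step. Open, on these data alone, is whether methoxy, an amine or a carboxylic acid at that carbon would shift the number. Also open, as far as these compounds go, is whether an ethyl or longer chain on the ring nitrogen would sit nearer compound 1 or compound 2.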